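The compounds below may be only part of what the source reports. "The series", "measured", "known", "first", "only" and "open" are said of these compounds alone.

In a functional assay on SK-HEP1 cells (Homo sapiens) for inhibition, read by MTT assay, with a stated time of 48 h (on this read-out lower numbers stand for stronger inhibition and higher numbers for weaker inhibition), compound 1 `C#Cc1cccc(Nc2nc(Nc3ccc(Cl)c(C(F)(F)F)c3)nc3cc(OC)c(OC)cc23)c1` gives 6800 nM, the highest of the two numbers recorded; compound 2 `C#Cc1cccc(Nc2nc(Nc3cc(C)ccc3F)nc3cc(OC)c(OC)cc23)c1` gives 4500 nM, and the step of a 1.5-fold lower number from compound 1 to compound 2 (0.18 log units; within the scatter). Compound 3 `C#Cc1cccc(Nc2nc(NCc3ccccc3)nc3cc(OC)c(OC)cc23)c1` differs from compound 1 by benzyl in place of 4-chloro-3-(trifluoromethyl)phenyl on a nitrogen on an aromatic ring. Going by the values given here, the only measured step, from compound 1 to compound 2, exchanges one aryl group for another and stays within the scatter; no measured step exchanges an aryl group for a benzyl group. Compound 3 is therefore expected to give a number near that of compound 1, with a 1.0-fold lower number from compound 1 to compound 3 (0.02 log units; within the scatter) not expected to exceed the scatter. The estimate for compound 3 in this assay is 6500 nM, within 2000 nM to 20000 nM.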

Compound 3, half-maximal inhibitory concentration: 2800 nM
Compound 3: the middle estimate sits 2.3-fold (0.37 log units) above what was measured; the range from low to high includes it.
By their numbers in this assay, from the lowest: compounds 3, 2 and 1 (each within the scatter of the next, the first and the last beyond it).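

In this assay, going by these compounds alone, benzyl in place of 4-chloro-3-(trifluoromethyl)phenyl gives a 2.4-fold lower number from compound 1 to compound 3 (0.39 log units; beyond the scatter), the first step at this position to pass beyond the scatter, and it shows that the nitrogen need not carry an aryl group directly. Measured against compound 2, the same kind of exchange gives a 1.6-fold lower number from compound 2 to compound 3 (0.21 log units; within the scatter), so the difference holds only against compound 1. Nothing at hand explains this difference. The compounds shown leave open whether unsubstituted phenyl would match benzyl, which would separate the effect of the added carbon from the loss of chlorine and trifluoromethyl. They also leave open how a longer chain such as phenethyl would compare.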